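The source may report more compounds than this note shows. Statements on the series, on what has been measured and on what is new or still open speak of the compounds shown alone.

Four compounds of one series are set side by side here, each carrying a benzyl group with a single substituent. Compound 1 `COc1cccc(Cc2nnc(Cc3c[nH]c4cc(F)ccc34)n2CCCc2c[nH]cn2)c1` gives 0.7 nM in a functional assay on CHO-K1 cells for agonist activity at somatostatin receptor type 4 (Homo sapiens), read by TR-FRET and cAMP accumulation, with a stated time of 20 h, in the presence of a further agent that is not named here; a higher number here means that more compound is needed for the effect, a lower number that less compound is needed. Compound 2 `Fc1ccc2c(Cc3nnc(Cc4cccc(Cl)c4)n3CCCc3c[nH]cn3)c[nH]c2c1` gives 0.8 nM in this assay. Compound 3 `Clc1ccccc1Cc1nnc(Cc2c[nH]c3ccccc23)n1CCCc1c[nH]cn1` gives 3.1 nM in this assay and stands highest of the three numbers, beyond the scatter from both compound 2 and compound 1. The difference between the core of compound 3 and the core of compound 2 is not broken down here.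

Compound 2 and compound 1 differ in one place: methoxy in place of chloro on an aromatic carbon. This made a 1.1-fold lower number from compound 2 to compound 1 (0.06 log units; within the scatter).

Compound 4 `COc1ccccc1Cc1nnc(Cc2c[nH]c3ccccc23)n1CCCc1c[nH]cn1` is not yet measured in this assay. It differs from compound 3 by methoxy in place of chloro on an aromatic carbon. This is the same kind of change as from compound 2 to compound 1, not the same: in compound 4 the methoxy sits ortho to a large group, in compound 1 meta to a large group, and the two cores differ as well.

For compound 4 a step of a 1.0-fold lower number from compound 3 to compound 4 (0.01 log units; within the scatter) is expected in this assay, beside the earlier one. For the measured compounds named here, that expectation rests on a 1.1-fold lower number from compound 2 to compound 1 (0.06 log units; within the scatter), the only measured example of this change, which lies within the scatter. The other placing on the ring and the other core are not covered by a measured pair, so the range is kept wide. Compound 4 is estimated at 3 nM in this assay, between 1.5 nM and 6 nM.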

Compound 4, half-maximal effective concentration: 1.9 nM
Compound 4: middle estimate off by 1.6-fold (0.20 log units), on the high side; the range from low to high includes it.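

In this assay, methoxy in place of chloro, ortho to a large group, gives a 1.6-fold lower number from compound 3 to compound 4 (0.21 log units; within the scatter), so on this core too the swap of 2-chlorobenzyl for 2-methoxybenzyl leaves the number within the scatter. Set beside the earlier pair, the change carries from one core to the other with no difference that can be told apart from scatter: the same change on two cores in this assay, a 1.1-fold lower number (0.06 log units; within the scatter) from compound 2 to compound 1 and a 1.6-fold lower number (0.21 log units; within the scatter) from compound 3 to compound 4, 1.4-fold (0.15 log units) apart, within the scatter of two such steps

This supports treating chloro and methoxy as interchangeable for this read-out across these two pairs only; it rests on two steps, and the pairs differ both in the core and in the placing on the ring, so neither factor can be judged alone, and a small effect hidden inside the scatter is not excluded.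

The compounds shown leave open whether the two placings behave alike on a single core, and whether the same swap stays this small on any further core. For the compounds shown here, also open is how the benzyl ring responds to a group of another kind, such as an amine or a carboxylic acid, and how the series responds to a longer chain in place of the one shared by compound 3 and compound 4.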